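Trading a 2-Phenylethenyl Arm for a Hydroxylated Thioether

The source may hold more compounds than are shown below. What is called first, only, known or untested is meant among the compounds shown, and "the series" means these compounds.

Among the compounds with values here, compound 1 `Nc1nc(O)c2c(n1)n(C1OC(CO)[C@@H](O)[C@H]1O)c(=O)n2C/C=C/c1ccccc1` is one of three compounds measured in a functional assay on the whole organism (B cells) with Mus musculus as the target; a higher number here means a larger maximal response, a lower number a smaller maximal response. In this assay compound 1 gives 73%, the second highest of the three numbers. Compound 2 `C=CCn1c(=O)n(C2CN(CCCC)CC(CO)O2)c2nc(N)nc(O)c21` gives 38%, beyond the scatter below compound 1, while compound 3 `C=CCn1c(=O)n(CCCCCCCC)c2nc(N)nc(O)c21` gives 130%, beyond the scatter above it. Compound 4 `Nc1nc(O)c2c(n1)n(C1OC(CO)[C@@H](O)[C@H]1O)c(=O)n2CC(O)CSc1ccccc1` differs from compound 1 in one place: 1-hydroxy-2-(phenylsulfanyl)ethyl in place of 2-phenylethenyl on a saturated chain carbon bound to an aromatic nitrogen. The entering group brings one hydrogen-bond donor and two hydrogen-bond acceptors where the leaving 2-phenylethenyl had none. Within the data shown here, no measured pair shows such a change, so its direction cannot be read from a comparable step. A modest downward step is expected, a number 13 percentage points lower from compound 1 to compound 4 (beyond the scatter), possibly within the scatter. Compound 4 is estimated at 60%, ranging from 25% to 110%.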

Compound 4, largest response reached (reported as maximal response), in percent of the reference or control that the assay uses: 12%
The estimate for compound 4 lay 48 percentage points above the measured number; measured number outside the range, below it.
By their numbers in this assay, from the lowest: compound 4; then compound 2; then compound 1; then compound 3.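

In this assay, putting 1-hydroxy-2-(phenylsulfanyl)ethyl in place of 2-phenylethenyl gives a number 61 percentage points lower from compound 1 to compound 4 (beyond the scatter) and shows that the response depends strongly on what this chain carbon carries, even though both groups hold the same six-membered aromatic ring. No measurement here accounts for the drop. This single step cannot show whether the hydroxy group, the sulfur or the change in the chain matters most. Going by these compounds, how an amine in place of the hydroxy group, or a plain longer carbon chain ending in the same ring, would behave remains open.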